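A few compounds are considered here, and "the series" means these few. Any claim that something is new, unique, unknown or untested is made for them only; others in the source may bear on it.

In a functional assay on the whole organism with Mus musculus as the target (on this read-out lower numbers stand for an effect already at smaller amounts and higher numbers for an effect only at larger amounts of compound), compound 1 (`NC(=O)/C=C1\CCc2c(F)cccc21`) gives > 100 mg/kg as its read-out, and this is a limit of the assay and not a number. In this assay, for the measured compounds named here, compound 2 (`CNC(=O)/C=C1\CCc2c(F)cc(F)cc21`) gives 45 mg/kg and so holds the only true number so far. Compound 3 (`NC(=O)/C=C1\CCc2c(F)cc(F)cc21`) has not yet been measured. The change from compound 2 is hydrogen in place of methyl on an amide-type nitrogen and amounts to hydrogen in place of methyl on an amide-type nitrogen. Going by the values given here, no measured pair isolates this change, so any expectation rests on compound 2 at 45 mg/kg and on the modest size of the swap. In this assay a small step toward lower doses is expected, although a result within the usual scatter would be no surprise. The estimated move is a 1.6-fold lower number from compound 2 to compound 3 (0.21 log units; within the scatter) and is expected to leave the read-out as a true number rather than a limit. For compound 3 the expected value is 28 mg/kg with an estimated range from 9 mg/kg to 85 mg/kg on the same read-out.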

Compound 3, dose for half-maximal effect: 69 mg/kg
Estimate against measurement, compound 3: 2.5-fold (0.39 log units) below; the measured number falls inside the stated range.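

In this assay, for the compounds shown here, this pair gives the first direct reading of the amide-type nitrogen, with a 1.5-fold higher number from compound 2 to compound 3 (0.19 log units; within the scatter) for hydrogen in place of methyl, so on the present numbers the methyl is not needed for activity at the level of compound 2 and this swap separates nothing beyond the scatter. Fluoro in place of hydrogen on an aromatic carbon now also has a reading, an at least 1.4-fold lower number from compound 1 to compound 3 (0.16 log units; that floor lies within the scatter), and compound 3 brings this comparison onto a true number on one side only. For compound 1 the read-out > 100 mg/kg is a limit of the assay and not a number, so the size of the fluoro step stays a floor and no more: the limit of > 100 mg/kg in this assay, at which 1 of the 3 values shown sits.

The compounds shown leave open whether a longer chain such as ethyl, or a ring such as cyclopropyl, on the amide-type nitrogen would separate from the methyl and hydrogen forms in this assay. They also leave open whether chloro or a nitrile in place of this fluoro would give a step beyond the scatter.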